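This account rests on a few compounds, and the source may have more. Where it says the series, first, only, none or still open, it means among the compounds named here.

Three compounds sharing one core were measured in a functional assay, read by spectrophotometry, with a stated time of 30 min; a lower number here means a stronger inhibitor, a higher number a weaker inhibitor. Compound 1 `Cc1nc2c3ccccc3ccc2c2nc3c(ccc4ccccc43)c(-c3cc([N+](=O)[O-])ccc3N)c12` gives 93.1 ug/mL. Compound 2 `Cc1nc2c3ccccc3ccc2c2nc3c(ccc4ccccc43)c(-c3ccccc3N)c12` carries hydrogen in place of the nitro group of compound 1; compound 2 gives 95.4 ug/mL, and the step is a 1.0-fold higher number from compound 1 to compound 2 (0.01 log units; within the scatter). Compound 3 `Cc1nc2c3ccccc3ccc2c2nc3c(ccc4ccccc43)c(-c3ccccc3Cl)c12` carries a chloro group where compound 2 carries an amino group; compound 3 gives 118 ug/mL. Its number sits within the usual scatter of both others: a 1.2-fold higher number from compound 2 to compound 3 (0.09 log units; within the scatter) and a 1.3-fold higher number from compound 1 to compound 3 (0.10 log units; within the scatter). Every exchange so far on that six-membered aromatic ring of carbon only has stayed within the scatter.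

Compound 4 `Cc1nc2c3ccccc3ccc2c2nc3c(ccc4ccccc43)c(-c3ccccc3S)c12` has not yet been measured. It differs from compound 3 by sulfanyl in place of chloro on an aromatic carbon. The step that bears most on it is the earlier exchange on the same aromatic carbon, a 1.2-fold higher number from compound 2 to compound 3 (0.09 log units; within the scatter), and the exchange elsewhere on the same ring, a 1.0-fold higher number from compound 1 to compound 2 (0.01 log units; within the scatter), stayed within the scatter as well. A further exchange of one small group for another at that carbon is therefore expected to move this assay by no more than the scatter, in no particular direction. Compound 4 is thus estimated to give 105 ug/mL, between 60 ug/mL and 180 ug/mL, which would be an expected step of a 1.1-fold lower number from compound 3 to compound 4 (0.05 log units; within the scatter) that stays within the scatter.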

Compound 4, half-maximal inhibitory concentration: 89 ug/mL
For compound 4 the middle estimate is 1.2-fold (0.07 log units) above the measured one; low and high end bracket the measured number.
By their numbers in this assay, from the lowest: compounds 4, 1, 2 and 3 (each within the scatter of the next).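

In this assay, sulfanyl now joins chloro and amino on this aromatic carbon, ortho to a large group, with no separation among them: the steps are a 1.3-fold lower number from compound 3 to compound 4 (0.12 log units; within the scatter) and a 1.1-fold lower number from compound 2 to compound 4 (0.03 log units; within the scatter), even though sulfanyl counts one hydrogen-bond donor and one hydrogen-bond acceptor where chloro counts none. Compound 4 also cannot be told apart from compound 1, which carries the 2-amino-5-nitrophenyl group, with a 1.0-fold lower number from compound 1 to compound 4 (0.02 log units; within the scatter) as the step, so no exchange on this ring among the four compounds has moved the number beyond the scatter. No measurement is available to explain why these numbers stay so close.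

As far as these compounds go, the groups on this ring so far are small single groups and a nitro group, so it stays open whether a carboxylic acid, a methoxy group or a longer alkyl chain on the same carbon would move the number beyond the scatter. Also open, from the compounds shown here alone, is whether the assay would respond to an exchange on the shared core itself rather than on this ring.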